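The source may hold more compounds than are shown below. What is called first, only, known or untested is meant among the compounds shown, and "the series" means these compounds.

Measured in an ADME assay on microsomes from liver (Homo sapiens) for metabolic stability, with a stated time of 30 min; on this read-out higher numbers stand for a more stable compound and lower numbers for a less stable compound:

- compound 1 `C[C@H](Nc1ccc(C#N)n(C)c1=O)c1cc2cc(Cl)c(OCC3CC3)cc2[nH]c1=O`: 82%
- compound 2 `O=c1[nH]c2ccc(Cl)cc2cc1CNc1cccn(C2CC2)c1=O`: 78%

In this assay, compound 1 at 82% cannot be told apart from compound 2 at 78%, since the two values lie within the scatter of each other. Going by the values given here, compound 1 therefore stands level with the only other measured compound.

Compound 3 `C[C@H](Nc1ccc(C#N)n(C)c1=O)c1cc2cc(Cl)c(O[C@H](C)c3ccccn3)cc2[nH]c1=O` keeps the core of compound 1 and alters one group: 1-(pyridin-2-yl)ethyl in place of cyclopropylmethyl on an oxygen on an aromatic ring. In words, 1-(pyridin-2-yl)ethyl takes the place of cyclopropylmethyl on an oxygen on an aromatic ring.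

Among the compounds with values here, no measured pair shows this or any similar change, so the size of the step in this assay rests on judgement alone. The value of compound 1, 82%, leaves little room for a rise, and a modest fall slightly beyond the scatter is expected, though a result within the scatter would be no surprise. The expected change is a number 12 percentage points lower from compound 1 to compound 3 (beyond the scatter). The estimated value for compound 3 is 70%, with an expected range from 50% to 88%.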

Compound 3, percent of the compound remaining: 70%
The estimate for compound 3 equals the measured number at the digits printed, and the stated range covers the measured number.
By their numbers in this assay, from the lowest: compounds 3, 2 and 1 (each within the scatter of the next, the first and the last beyond it).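

In this assay, putting 1-(pyridin-2-yl)ethyl in place of cyclopropylmethyl on an oxygen on an aromatic ring gives a modest change: a number 12 percentage points lower from compound 1 to compound 3 (beyond the scatter). Going by these compounds alone, this is the first reading of this position, and it shows that a group of 8 heavy atoms, with a six-membered aromatic ring and a defined stereocentre, can replace one of 4 heavy atoms there while compound 3 still stands at 70%. Within the data shown here, the single step changes size, ring type, hetero atom count and stereochemistry together, so it cannot assign the fall to any one of them, and nothing available bears on why the number falls.

The compounds shown leave open whether the fall follows the ring nitrogen, the branched carbon or the configuration of the stereocentre. A benzyl or pyridin-2-ylmethyl group on the same oxygen, or the mirror-image form of 1-(pyridin-2-yl)ethyl, would separate these features, and a plain methyl group would show how the read-out responds to a much smaller group there.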